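The source may report more compounds than this note shows. Statements on the series, on what has been measured and on what is new or still open speak of the compounds shown alone.

Measured so far in an assay on membranes from CHO cells for displacement of a labelled ligand from adenosine receptor A1 (Homo sapiens), read by scintillation counting, with a stated time of 60 min, tested at 1 uM; a higher number here means more inhibition at the concentration tested (going by the name of the read-out), a lower number less inhibition: compound 1 `CCCOC(=O)C1=C(C)N(C)C(=O)NC1c1ccco1` gives 3%, compound 2 `CC1=C(C(=O)OCC(C)C)C(c2ccco2)NC(=O)N1C` gives 13%, and compound 3 `COC(=O)C1=C(C)N(C)C(=O)NC1c1cccs1` gives 30%.

Compound 1 and compound 2 differ in one place, (methyl in place of hydrogen on a saturated chain carbon bound to two saturated chain carbons). This change made a number 10 percentage points higher from compound 1 to compound 2 (within the scatter). Compound 3 rests on a different core; the difference between the two cores is not broken down here. In this assay compound 3 stands highest, beyond the scatter from both others.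

Compound 4 `CCOC(=O)C1=C(C)N(C)C(=O)NC1c1cccs1` is not yet measured. It differs from compound 3 by methyl in place of hydrogen on a saturated chain carbon bound to an oxygen next to a carbonyl group. For the measured compounds named here, this is the same kind of change as the one from compound 1 to compound 2, but not the same: there the place was a saturated chain carbon bound to two saturated chain carbons, here it is a saturated chain carbon bound to an oxygen next to a carbonyl group. Going by a number 10 percentage points higher from compound 1 to compound 2 (within the scatter), the step is expected to be a number 6 percentage points higher from compound 3 to compound 4 (within the scatter). Compound 4 is therefore estimated at 36%, likely between 15% and 57%.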

Compound 4, a percentage reported as inhibition, at one concentration (the size of the read-out at that concentration, not a potency): 1%
Compound 4: middle estimate off by 35 percentage points, on the high side; the measured number lies below the stated range.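

Turning methoxycarbonyl into ethoxycarbonyl in this assay gave a number 29 percentage points lower from compound 3 to compound 4 (beyond the scatter). The addition of one methyl did not carry over from one core to the other in these compounds: the same change on two cores in this assay, a number 10 percentage points higher (within the scatter) from compound 1 to compound 2 and a number 29 percentage points lower (beyond the scatter) from compound 3 to compound 4, 39 percentage points apart, beyond the scatter of two such steps. For the compounds shown here, with only one pair on each core, and the methyl added at a different place on the chain in each pair, this does not show whether the core or the place lies behind the gap, and it gives no rule for the wider series.

As far as these compounds go, it remains open how a longer chain or a carboxylic acid in place of the ethoxycarbonyl would read on the core of compound 3. Also open, from the compounds shown here alone, is what a methyl added at that same place would do on the core of compound 1.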